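Cytotoxicity of Aryl Amide Analogues Toward Compound 4

A few compounds are considered here, and "the series" means these few. Any claim that something is new, unique, unknown or untested is made for them only; others in the source may bear on it.

Measured compounds:
- compound 1, `CCN(CC)C(=O)Nc1ncc(C(Oc2ccc3cc(Br)ccc3c2)c2ccc(Cl)cc2)s1`: "not toxic" (no number reported)
- compound 2, `Cc1ccc(C(=O)Nc2ncc(C(Oc3ccc4cc(Br)ccc4c3)c3ccc(Cl)cc3)s2)cc1`: "not toxic" (no number reported)
- compound 3, `O=C(Nc1ncc(C(Oc2ccc3cc(Br)ccc3c2)c2ccc(Cl)cc2)s1)c1ccc(F)cc1Br`: > 50000 nM

Three compounds of this series have been examined in an ADME assay on HepG2 2.2.15 cells (Homo sapiens) for cytotoxicity; on this read-out lower numbers stand for higher toxicity in this test and higher numbers for lower toxicity in this test. Compound 1 is recorded as "not toxic" (no number reported), and compound 2 likewise as "not toxic" (no number reported), both without a single number. Compound 3 is reported only as a limit of this assay, > 50000 nM, so its true value is not known beyond that boundary; it sits at the limit of > 50000 nM in this assay, at which 1 of the 3 values shown sits. No pair of these compounds differs in just one place, so no measured step is available to guide expectations.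

Compound 4, `N#Cc1cccc(C(=O)Nc2ncc(C(Oc3ccc4cc(Br)ccc4c3)c3ccc(Cl)cc3)s2)c1`, has not yet been tested. It differs from compound 3 by 3-cyanophenyl in place of 2-bromo-4-fluorophenyl on a carbonyl carbon. With every compound examined so far showing no measurable cytotoxicity, no step beyond the usual scatter is expected in this assay, and the estimated change is a step that the limit leaves unreadable from compound 3 to compound 4. Compound 4 is therefore expected to give about 60000 nM in this assay, within a range from 20000 nM to 150000 nM, most likely again reported only as a limit.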

Compound 4, half-maximal cytotoxic concentration: > 50000 nM
Compound 4: a limit, no number (the forecaster's own chance of this, stated with the estimate: 80%); the middle value lies beyond the limit too.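

No step from compound 3 to compound 4 can be read in this assay, since both results are only limits: the limit of > 50000 nM in this assay, at which 2 of the 4 values shown sit.

The compounds shown leave open how far any of them lies from that limit, and whether any group on the carbonyl carbon would give a measurable cytotoxic concentration.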